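Replacing the ring-bearing side chain of compound 3

This account rests on a few compounds, and the source may have more. Where it says the series, first, only, none or still open, it means among the compounds named here.

In a functional assay on K562 cells (Homo sapiens) for cytotoxicity, read by fluorescence, with a stated time of 72 h (on this read-out lower numbers stand for stronger inhibition and higher numbers for weaker inhibition), compound 1 (`CC(C)c1n[nH]c2c(NCc3ccc(-c4ccccn4)cc3)nc(NCCO)nc12`) gives 38 nM, compound 2 (`CC(C)c1n[nH]c2c(NCc3ccc(-c4ccccn4)cc3)nc(NCC(C)(C)O)nc12`) gives 29 nM, and compound 3 (`CC(C)c1n[nH]c2c(NCc3ccc(-c4ccccn4)cc3)nc(N3CCCCC3CCO)nc12`) gives 165 nM, the highest number of the three. Compound 4 (`CC(C)c1n[nH]c2c(NCc3ccc(-c4ccccn4)cc3)nc(NCCN)nc12`) carries (2-aminoethyl)amino in place of 2-(2-hydroxyethyl)piperidin-1-yl on an aromatic carbon. Two measured steps lead the opposite way, into the ring-bearing chain: a 4.3-fold higher number from compound 1 to compound 3 (0.64 log units; beyond the scatter) and a 5.7-fold higher number from compound 2 to compound 3 (0.76 log units; beyond the scatter). Between the open chains, the change is small: a 1.3-fold lower number from compound 1 to compound 2 (0.12 log units; within the scatter). Within the data shown here, no measured compound carries (2-aminoethyl)amino, so that group itself is untested. A reversal of similar size is therefore expected, giving a 3.7-fold lower number from compound 3 to compound 4 (0.56 log units; beyond the scatter). Compound 4 is estimated at 45 nM, with an expected range of 15 nM to 130 nM.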

Compound 4, half-maximal inhibitory concentration: 63 nM
The estimate for compound 4 lay 1.4-fold (0.15 log units) below the measured number, and the stated range covers the measured number.
By their numbers in this assay, from the lowest: compounds 2, 1 and 4 (each within the scatter of the next, the first and the last beyond it); then compound 3.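

Going from the ring-bearing chain to the open (2-aminoethyl)amino chain gives a 2.6-fold lower number from compound 3 to compound 4 (0.42 log units; beyond the scatter) in this assay and shows that this position also accepts a chain ending in amino rather than hydroxy. On the open chain, amino in place of hydroxy gives a 1.7-fold higher number from compound 1 to compound 4 (0.22 log units; within the scatter) and so leaves the number effectively unchanged. Aminomethyl in place of 1-hydroxy-1-methylethyl gives a 2.2-fold higher number from compound 2 to compound 4 (0.34 log units; beyond the scatter) and is the only one of these two open-chain changes beyond the scatter. From the compounds shown here alone, how a longer chain ending in amino or a terminal carboxylic acid would read here remains open. Nothing available explains these differences.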